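A Second Chloro on the Benzyl Sulfide

The source may hold more compounds than are shown below. What is called first, only, known or untested is meant among the compounds shown, and "the series" means these compounds.

Compound 1 `Cc1ccsc1/C=C(/SCc1ccc(Cl)cc1)C(=O)c1ccc(Cl)cc1` and compound 2 `Cc1ccsc1/C=C(/SCc1ccc(Cl)c(Cl)c1)C(=O)c1ccc(Cl)cc1` share one core and differ by chloro in place of hydrogen on an aromatic carbon. In a functional assay on DU-145 cells (Homo sapiens) for inhibition, read by trypan blue exclusion, with a stated time of 96 h (a lower number here means a stronger inhibitor of growth, a higher number a weaker inhibitor of growth), compound 1 gives 50000 nM, and compound 2 gives 50000 nM; the step of no change at the digits printed from compound 1 to compound 2 (within the scatter). Compound 3 `O=C(O)c1ccc(C(=O)/C(=C\c2ccc(Br)c([N+](=O)[O-])c2)SCc2ccc(Cl)cc2)cc1` stands on another core, and the difference between the two cores is not broken down here. In this assay compound 3 is reported as a limit of the assay, < 1000 nM. That point is the limit of < 1000 nM in this assay, at which 1 of the 3 values shown sits. Compound 4 `O=C(O)c1ccc(C(=O)/C(=C\c2ccc(Br)c([N+](=O)[O-])c2)SCc2ccc(Cl)cc2Cl)cc1` carries the same kind of change from compound 3 as compound 2 does from compound 1, (chloro in place of hydrogen on an aromatic carbon); around the place the surroundings differ, the new chloro in compound 4 being ortho to a large group and meta to a chloro group, whereas in compound 2 it is ortho to a chloro group and meta to a large group. Compound 4 is expected to move little, an expected step that the limit leaves unreadable from compound 3 to compound 4, as the earlier step of no change at the digits printed from compound 1 to compound 2 (within the scatter) moved nothing. Compound 4 is therefore estimated at 500 nM, between 100 nM and 2000 nM, with a fair chance that only a limit is reported again.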

Compound 4, concentration for 50% growth inhibition: 1000 nM
For compound 4 the middle estimate is 2.0-fold (0.30 log units) below the measured one; the measured number falls inside the stated range.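

In this assay the added chloro gives a number no lower from compound 3 to compound 4 (the limit leaves the size open). Set side by side in this assay, chloro in place of hydrogen on an aromatic carbon can be compared across the two cores only loosely: the same change on two cores in this assay, no change at the digits printed (within the scatter) from compound 1 to compound 2 and a number no lower (the limit leaves the size open) from compound 3 to compound 4; the limit leaves it open whether they differ. Compound 3 is reported only as a limit of the assay, < 1000 nM, and the size of the step that starts from it cannot be read: the limit of < 1000 nM in this assay, at which 1 of the 4 values shown sits. This shows that the added chloro gives a lower number on neither core, but it does not show whether the change carries over from one core to the other with the same size, so a real loss on the core of compound 3 remains possible.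

The compounds shown leave open whether a fluoro or a methoxy group at the place of the new chloro on the benzyl sulfide would give the same result. They also leave open how the 2,4-dichlorobenzyl group would behave on the core of compound 1, and what an amine in place of the nitro group would do on the core of compound 3.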